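The compounds below may be only part of what the source reports. "The series", "measured", "known", "first", "only" and "open" are said of these compounds alone.

Among the measured compounds shown here, in a functional assay on Shh Light II cells (Mus musculus) for inhibition, read by a luciferase reporter (on this read-out higher numbers stand for weaker inhibition and lower numbers for stronger inhibition), compound 1 (`O=C(OC1CCCCC1)N1CCC(c2nc(-c3ccc4ccccc4n3)no2)CC1`) gives 580 nM and compound 2 (`COc1ccccc1OC(=O)N1CCC(c2nc(-c3ccc4ccccc4n3)no2)CC1`) gives 250 nM, the lower of the two numbers so far. Compound 3 (`O=C(Nc1cccnc1Cl)N1CCC(c2nc(-c3ccc4ccccc4n3)no2)CC1`) has not yet been measured. It carries (2-chloropyridin-3-yl)amino in place of 2-methoxyphenoxy on a carbonyl carbon. For the measured compounds named here, only one measured step bears on this change, and only loosely: a 2.3-fold lower number from compound 1 to compound 2 (0.37 log units; beyond the scatter). That modest step swapped cyclohexyl for 2-methoxyphenyl, and both compounds keep the oxygen on the carbonyl carbon. Neither measured compound has an amino group there, so the data give no direction for the new change. The step expected in this assay is therefore small, and the estimate is a 1.1-fold lower number from compound 2 to compound 3 (0.06 log units; within the scatter), within the scatter but with real uncertainty on either side. Compound 3 is estimated at 220 nM, with an expected range from 50 nM to 1000 nM.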

Compound 3, half-maximal inhibitory concentration: 1600 nM
Estimate against measurement, compound 3: 7.3-fold (0.86 log units) below, outside the stated range (above it).
By their numbers in this assay, from the lowest: compound 2; then compound 1; then compound 3.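

Among the compounds shown here, with an amino group on the carbonyl carbon for the first time, the number in this assay moved clearly upward: replacing 2-methoxyphenoxy gave a 6.4-fold higher number from compound 2 to compound 3 (0.81 log units; beyond the scatter), and replacing cyclohexyloxy gave a 2.8-fold higher number from compound 1 to compound 3 (0.44 log units; beyond the scatter). This shows that the group on this carbonyl carbon can shift the read-out in the weaker direction as well as the stronger, and that (2-chloropyridin-3-yl)amino stands above both oxygen-linked groups. Nothing shown here accounts for the rise. The change alters the linking atom, the aromatic ring, the chlorine and the hydrogen-bond donor together, so the compounds shown leave open which of these carries the step. Phenylamino or pyridinyloxy on the same carbonyl carbon would bear on that question.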